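The source may hold more compounds than are shown below. What is called first, only, known or untested is meant among the compounds shown, and "the series" means these compounds.

Compound 3 `COc1cc2c(Oc3ccc(NC(=O)c4nn(-c5ccccc5)c(=O)c5ccccc45)cc3F)ccnc2cc1OCCCN1CCC(C)CC1` gives 580 nM in a functional assay on MKN-45 cells (Homo sapiens) for cytotoxicity, read by MTT assay, with a stated time of 72 h; on this read-out lower numbers stand for stronger inhibition and higher numbers for weaker inhibition. Among the three measured compounds it holds the second highest number. Compound 1 `COc1cc2c(Oc3ccc(NC(=O)c4nn(-c5ccccc5)c(=O)c5ccccc45)cc3F)ccnc2cc1OCCCN1CCN(C)CC1` gives 620 nM, and the step of a 1.1-fold lower number from compound 1 to compound 3 (0.03 log units; within the scatter) stays within the scatter. Compound 2 `COc1cc2c(Oc3ccc(NC(=O)c4nn(-c5ccc(F)cc5)c(=O)c5ccccc45)cc3F)ccnc2cc1OCCCN1CCN(C)CC1` gives 150 nM, the lowest number of the three; the step of a 4.1-fold lower number from compound 1 to compound 2 (0.62 log units; beyond the scatter) lies beyond the scatter.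

Compound 4 `COc1cc2c(Oc3ccc(NC(=O)c4nn(-c5ccc(F)cc5)c(=O)c5ccccc45)cc3F)ccnc2cc1OCCCN1CCC(C)CC1` is not yet measured. It differs from compound 3 by fluoro in place of hydrogen on an aromatic carbon; cut one bond further out, the same difference reads phenyl to 4-fluorophenyl. Among the measured compounds shown here, the only measured step that bears on this change is a 4.1-fold lower number from compound 1 to compound 2 (0.62 log units; beyond the scatter), in which the same fluoro entered on the same aromatic carbon of the shared core. The change from compound 3 to compound 4 is therefore expected to lower the number in this assay by a comparable amount, a 3.9-fold lower number from compound 3 to compound 4 (0.59 log units; beyond the scatter). On this basis compound 4 is expected to give about 150 nM in this assay, with a range from 70 nM to 350 nM.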

Compound 4, half-maximal inhibitory concentration: 130 nM
Compound 4: middle estimate off by 1.2-fold (0.06 log units), on the high side; the range from low to high includes it.
By their numbers in this assay, from the lowest: compounds 4 and 2 (each within the scatter of the next); then compounds 3 and 1 (each within the scatter of the next).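

On a second core, in this assay, phenyl to 4-fluorophenyl gives a 4.5-fold lower number from compound 3 to compound 4 (0.65 log units; beyond the scatter), so the effect of this fluoro no longer rests on a single pair. Its size carries over between the two cores: the same change on two cores in this assay, a 4.1-fold lower number (0.62 log units; beyond the scatter) from compound 1 to compound 2 and a 4.5-fold lower number (0.65 log units; beyond the scatter) from compound 3 to compound 4, 1.1-fold (0.03 log units) apart, within the scatter of two such steps. The exchange of 4-methylpiperazin-1-yl for 4-methylpiperidin-1-yl also stays small with the fluoro in place, at a 1.2-fold lower number from compound 2 to compound 4 (0.06 log units; within the scatter), and the two changes therefore appear independent in these four compounds: the same change on two cores in this assay, a 1.1-fold lower number (0.03 log units; within the scatter) from compound 1 to compound 3 and a 1.2-fold lower number (0.06 log units; within the scatter) from compound 2 to compound 4, 1.1-fold (0.03 log units) apart, within the scatter of two such steps.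

These compounds leave open whether chloro or methoxy in the same place would lower the number as far as fluoro, and whether fluoro on another carbon of that ring would do the same. On these data alone, how a morpholin-4-yl group at the end of the chain would behave also remains open.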